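Furan to methoxyphenyl amide exchange on the shared core

The source may hold more compounds than are shown below. What is called first, only, known or untested is meant among the compounds shown, and "the series" means these compounds.

Compound 1 `O=C(Nc1ccc(Cl)cc1CN1C(=O)c2ccccc2C1=O)c1ccco1` is the reference point in an assay on CHO cells for positive allosteric modulation of metabotropic glutamate receptor 5 (Rattus norvegicus), read by FLIPR; on this read-out higher numbers stand for an effect only at larger amounts of compound and lower numbers for an effect already at smaller amounts. In this assay compound 1 gives < 1000 nM, a limit of the assay rather than a number. Compound 2 `O=C(Nc1ccc(Cl)cc1CN1C(=O)c2ccccc2C1=O)c1ccccc1C(F)(F)F` carries 2-(trifluoromethyl)phenyl in place of furan-2-yl on a carbonyl carbon. In this assay compound 2 gives < 1000 nM, again a limit and not a number. The step that the two limits leave unreadable from compound 1 to compound 2 is therefore unreadable in size, as both values sit at the limit of < 1000 nM in this assay, at which 2 of the 2 values shown sit.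

Compound 3 `COc1ccccc1C(=O)Nc1ccc(Cl)cc1CN1C(=O)c2ccccc2C1=O` differs from compound 1 as follows: 2-methoxyphenyl in place of furan-2-yl on a carbonyl carbon. Going by the values given here, the only measured step at this carbonyl carbon, to compound 2, replaces furan-2-yl with another aryl group and leaves the value at the limit, so the exchange to 2-methoxyphenyl is expected to behave alike. The expected step that the limit leaves unreadable from compound 1 to compound 3 is small, with a good chance that this assay again reports only a limit. Compound 3 is therefore estimated at 300 nM, in the range 50 nM to 1500 nM.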

Compound 3, half-maximal effective concentration: < 1000 nM
Compound 3: no number, only a limit; the forecaster's own chance of this, stated with the estimate: 70%; the middle value does not contradict the limit.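

Going by these compounds alone, no step among compound 1, compound 2 and compound 3 can be read in this assay, as all three values are limits and not numbers: the limit of < 1000 nM in this assay, at which 3 of the 3 values shown sit. The compounds shown leave open how far the furan-2-yl, 2-(trifluoromethyl)phenyl and 2-methoxyphenyl amides differ from one another in this assay.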